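The source may hold more compounds than are shown below. What is called first, only, known or untested is meant among the compounds shown, and "the series" means these compounds.

Of the compounds shown here, three sharing one core have been measured in an ADME assay on microsomes from liver (Homo sapiens) for metabolic stability, read by LC-MS, using NADPH, with a stated time of 45 min, tested at 0.5 uM; on this read-out higher numbers stand for fast clearance and lower numbers for slow clearance. Compound 1 `CC1CCCN1C(=O)CCSc1nc2cc(Cl)ccc2o1` gives 8.5 mL/min/g. Compound 2 `O=C(CCSc1nc2cc(Cl)ccc2o1)N1CCC1` gives 3.7 mL/min/g. Compound 3 `CN(C(=O)CCSc1nc2cc(Cl)ccc2o1)C1CCS(=O)(=O)C1` gives 1.5 mL/min/g, the lowest of the three numbers; the gap from compound 3 up to compound 2 is beyond the scatter, as is the larger gap up to compound 1.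

The next compound, compound 4 `CN(C)C(=O)CCSc1nc2cc(Cl)ccc2o1`, differs from compound 3 in one place: methyl in place of 1,1-dioxothiolan-3-yl on an amide-type nitrogen. Among the compounds with values here, the one measured step that also alters the group on the amide-type nitrogen is a 2.3-fold lower number from compound 1 to compound 2 (0.36 log units; beyond the scatter), a modest change. Within the data shown here, no measured step covers the present change itself, and compound 3 stands apart from the two other compounds, so what is known is that the amide substituent moves the number, but by modest amounts. A rise in this assay from compound 3 is therefore expected, landing near where compound 2 sits rather than near compound 1, with the step of a 2.0-fold higher number from compound 3 to compound 4 (0.30 log units; within the scatter) expected. Compound 4 is estimated at 3 mL/min/g, within a range from 1.5 mL/min/g to 6 mL/min/g.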

Compound 4, intrinsic clearance in a liver preparation (reported as CLH), per the amount of preparation that the assay uses: 2.7 mL/min/g
Estimate against measurement, compound 4: 1.1-fold (0.05 log units) above; measured number inside the range.
By their numbers in this assay, from the lowest: compounds 3, 4 and 2 (each within the scatter of the next, the first and the last beyond it); then compound 1.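

In this assay, the swap of the 1,1-dioxothiolan-3-yl on the amide-type nitrogen for methyl gives a 1.8-fold higher number from compound 3 to compound 4 (0.26 log units; within the scatter), so the much larger ring group cannot be told apart from a single methyl here. Dimethylamino in place of azetidin-1-yl gives a 1.4-fold lower number from compound 2 to compound 4 (0.14 log units; within the scatter), whereas dimethylamino in place of 2-methylpyrrolidin-1-yl gives a 3.1-fold lower number from compound 1 to compound 4 (0.50 log units; beyond the scatter), which makes 2-methylpyrrolidin-1-yl the only one of these amide groups whose number stands clear of compound 4. Nothing shown gives a reason for these differences.

As far as these compounds go, whether the ring of compound 1 or its methyl carries that separation remains open, and an unsubstituted pyrrolidin-1-yl amide would address this. From the compounds shown here alone, how a basic amine or a carboxylic acid on the amide-type nitrogen would read in this assay also remains open.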